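A few compounds are considered here, and "the series" means these few. Any claim that something is new, unique, unknown or untested is made for them only; others in the source may bear on it.

The measured compounds:
Compound 1, `COc1ccc(-c2cc(-c3ccc(C(F)(F)F)cc3)cnc2N)cn1`, in a physicochemical assay for solubility, read by nephelometry, measured as kinetic solubility, at pH 2 (on this read-out lower numbers stand for lower solubility and higher numbers for higher solubility), gives > 100 ug/mL, which is a limit of the assay rather than a number.
Compound 2, `COc1ccc(-c2cc(-c3ccc(-n4cccn4)cc3)cnc2N)cn1`, gives > 100 ug/mL, likewise a limit.
Compound 3, `COc1ccc(-c2cc(-c3ccc(C(=O)O)cc3)cnc2N)cn1`, gives 12.5 ug/mL.

Going by the values given here, compound 3 therefore carries the only real number among the three; the other two readings sit at the limit of > 100 ug/mL in this assay, at which 2 of the 3 values shown sit. Compound 4, `COc1ccc(-c2cc(-c3ccc(C(=O)N(C)C)cc3)cnc2N)cn1`, differs from compound 3 in one place: dimethylamino in place of hydroxy on a carbonyl carbon. Among the compounds with values here, two measured steps bear on this change, both running the opposite way, from a neutral group to the carboxy. The step of an at least 8.0-fold lower number from compound 1 to compound 3 (0.90 log units; beyond the scatter) and the step of an at least 8.0-fold lower number from compound 2 to compound 3 (0.90 log units; beyond the scatter) each show that bringing the carboxy in lowered the reading markedly, whereas the step that the two limits leave unreadable from compound 1 to compound 2 between the two neutral groups tells nothing. Taking the carboxy away again, as the change from compound 3 to compound 4 does, should thus be expected to move the number back up, roughly undoing those drops; the expected step is a 6.4-fold higher number from compound 3 to compound 4 (0.81 log units; beyond the scatter). Compound 4 is accordingly estimated at 80 ug/mL in this assay, with a likely range from 30 ug/mL to 150 ug/mL, and a fair chance that the assay again reports only a limit.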

Compound 4, solubility: > 100 ug/mL
Compound 4 was reported as a limit (the forecaster's own chance of this, stated with the estimate: 45%); at least 1.2-fold (0.09 log units) between middle value and limit.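

In this assay, going by these compounds alone, the earlier steps to compound 3 replaced a whole group on an aromatic carbon, so they could not show whether the carbonyl carbon itself went with the low reading. Here that carbonyl carbon stays and only the atoms on it change, giving an at least 8.0-fold higher number from compound 3 to compound 4 (0.90 log units; beyond the scatter). Compound 4 therefore shows that a carbonyl at this position is compatible with a high reading, and that swapping hydroxy for dimethylamino on that carbon is enough to produce the whole step. The steps linking compound 4 to compound 1 and compound 2 cannot be read, so these three compounds cannot be ranked against one another: the limit of > 100 ug/mL in this assay, at which 3 of the 4 values shown sit.

The compounds shown leave open how far compound 4 lies past the limit, and so the full size of this step. They also leave open where other groups on the same carbonyl carbon would fall in this assay: a plain amino group, which keeps hydrogens on the nitrogen as hydroxy keeps one on the oxygen, or a methoxy group, which has none, could help separate the effect of that hydrogen from the effect of swapping oxygen for nitrogen.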